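The source may hold more compounds than are shown below. What is called first, only, known or untested is meant among the compounds shown, and "the series" means these compounds.

Within a functional assay on cells (Cancer cell lines, Homo sapiens) for cytotoxicity, read by sulforhodamine B assay, with a stated time of 48 h (on this read-out lower numbers stand for stronger inhibition of growth and higher numbers for weaker inhibition of growth), compound 2 `COc1ccc(C2=NN(C3=NC(=O)/C(=C4\C(=O)Nc5ccc(Br)cc54)S3)C(c3ccc(OC)cc3)C2)cc1` holds the highest number of the three measured, at 25300 nM. Compound 1 `COc1ccc(C2CC(c3ccccc3)=NN2C2=NC(=O)/C(=C3\C(=O)Nc4ccc(Br)cc43)S2)cc1` gives 390 nM and compound 3 `COc1ccc(C2=NN(C3=NC(=O)/C(=C4\C(=O)Nc5ccc(Cl)cc54)S3)C(c3ccc(OC)cc3)C2)cc1` gives 430 nM. The step of a 65-fold higher number from compound 1 to compound 2 (1.81 log units; beyond the scatter) and the step of a 59-fold lower number from compound 2 to compound 3 (1.77 log units; beyond the scatter) are both large, so compound 2 stands apart from either neighbour by a single change. Compound 4 `COc1ccc(C2=NN(C3=NC(=O)/C(=C4\C(=O)Nc5ccc(Br)cc54)S3)C(c3ccc(Cl)cc3)C2)cc1` differs from compound 2 by chloro in place of methoxy on an aromatic carbon. The step of a 65-fold higher number from compound 1 to compound 2 (1.81 log units; beyond the scatter) bears most directly on this, since the methoxy that is removed there is the one that leaves here; chloro rather than hydrogen enters, so a smaller reversal is expected. Compound 4 is therefore estimated at 1200 nM, between 250 nM and 8000 nM, a step of a 21-fold lower number from compound 2 to compound 4 (1.32 log units; beyond the scatter).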

Compound 4, concentration for total growth inhibition: 7440 nM
Compound 4: middle estimate off by 6.2-fold (0.79 log units), on the low side, within the range that was stated.
By their numbers in this assay, from the lowest: compounds 1 and 3 (each within the scatter of the next); then compound 4; then compound 2.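

In this assay, chloro in place of methoxy at this position gives only a 3.4-fold lower number from compound 2 to compound 4 (0.53 log units; beyond the scatter), a modest change. The group replaced is the other of the two 4-methoxyphenyl groups of compound 2, not the one that differs in a 65-fold higher number from compound 1 to compound 2 (1.81 log units; beyond the scatter); the two steps describe separate positions, and the larger step does not carry over to this one. No measured evidence accounts for the difference in size.

Still open, from the compounds shown here alone, is how an amine or a carboxylic acid in this place would read. Also open, going by these compounds, is whether the step holds when chloro replaces bromo on the core.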